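Chloro for Methyl: Expected Cytotoxicity of Compound 3

This account rests on a few compounds, and the source may have more. Where it says the series, first, only, none or still open, it means among the compounds named here.

Measured compounds:
Compound 1, `Cc1ccc(-n2cc(-c3ccccc3NS(=O)(=O)c3c[nH]c(=O)[nH]c3=O)nn2)cc1`, gives 32400 nM in an ADME assay on GES1 cells (Homo sapiens) for cytotoxicity, read by MTT assay, with a stated time of 24 h; on this read-out higher numbers stand for lower toxicity in this test and lower numbers for higher toxicity in this test.
Compound 2, `Cc1ccccc1-n1cc(-c2ccc(NS(=O)(=O)c3c[nH]c(=O)[nH]c3=O)cc2)nn1`, is recorded in this assay as "not toxic" (no number reported), with no number reported.

Both compounds share a core in which a sulfonamide links two aromatic parts, and both were tested in this assay. Compound 1 gives a measurable half-maximal cytotoxic concentration, while compound 2 stands without a single number: it was simply reported as not toxic, so its position cannot be placed on the same scale as compound 1.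

Compound 3, `O=c1[nH]cc(S(=O)(=O)Nc2ccc(-c3cn(-c4ccccc4Cl)nn3)cc2)c(=O)[nH]1`, has not yet been measured. It differs from compound 2 in one place: chloro in place of methyl on an aromatic carbon. Within the data shown here, with no measured pair in this set showing what such a swap does, the expectation is a step of no more than the usual scatter, in no particular direction. Compound 3 is therefore expected to show low toxicity, estimated at 40000 nM, within a range of 15000 nM to 150000 nM, with a fair chance that only a limit is reported.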

Compound 3, half-maximal cytotoxic concentration: 16400 nM
Estimate against measurement, compound 3: 2.4-fold (0.39 log units) above, and the stated range covers the measured number.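

In this assay compound 3 gives 16400 nM and compound 2 is recorded only as not toxic, without a number, so no step can be read between these two compounds. From the compounds shown here alone, what the change from 2-methylphenyl to 2-chlorophenyl does in this assay stays open. Nothing shown here offers an explanation for the value of compound 3.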